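This account rests on a few compounds, and the source may have more. Where it says the series, first, only, none or still open, it means among the compounds named here.

Compound 1 `COc1cccc(-c2c(C)n(Cc3c(F)cccc3F)c(=O)n(C[C@H](N)C(C)C)c2=O)c1F`: 51 nM
Compound 2 `COc1cccc(-c2c(C)n(Cc3c(F)cccc3F)c(=O)n(C[C@@H](N)C3CCCC3)c2=O)c1F`: 94 nM
Compound 3 `COc1cccc(-c2c(C)n(Cc3c(F)cccc3F)c(=O)n(C[C@H](NC(C)C)C3CCCC3)c2=O)c1F`: 12 nM

All three were tested in an assay on HEK293 cells for binding affinity to Gonadotropin-releasing hormone receptor (Homo sapiens), read by radioligand binding; on this read-out lower numbers stand for stronger inhibition and higher numbers for weaker inhibition. Compound 1 gives the second highest of the three numbers; its nearest neighbour is compound 2, and the two lie within the scatter of each other (a 1.8-fold higher number from compound 1 to compound 2 (0.27 log units; within the scatter)). Compound 3 stands furthest from compound 1 (a 4.3-fold lower number from compound 1 to compound 3 (0.63 log units; beyond the scatter)) and is also beyond the scatter from compound 2 (a 7.8-fold lower number from compound 2 to compound 3 (0.89 log units; beyond the scatter)).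

Compound 4 `COc1cccc(-c2c(C)n(Cc3c(F)cccc3F)c(=O)n(C[C@@H](N)C3CCCCC3)c2=O)c1F` has not yet been measured. It differs from compound 1 in one place: amino(cyclohexyl)methyl in place of 1-amino-2-methylpropyl on a saturated chain carbon bound to an aromatic nitrogen. Of the measured steps, a 1.8-fold higher number from compound 1 to compound 2 (0.27 log units; within the scatter) bears most directly on this change, since there too the 1-amino-2-methylpropyl gave way to a group carrying a ring of carbon only while the amine stayed unsubstituted, and that step fell within the scatter. The steps ending at compound 3 involve an isopropylamino group as well and so speak less directly. Compound 4 is therefore expected to show a 1.6-fold higher number from compound 1 to compound 4 (0.20 log units; within the scatter) in this assay, no step beyond the scatter. Compound 4 is estimated at 80 nM, with a range from 30 nM to 220 nM.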

Compound 4, inhibition constant: 46 nM
Compound 4: the middle estimate sits 1.7-fold (0.24 log units) above what was measured; measured number inside the range.
By their numbers in this assay, from the lowest: compound 3; then compounds 4, 1 and 2 (each within the scatter of the next, the first and the last beyond it).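

In this assay, amino(cyclohexyl)methyl in place of 1-amino-2-methylpropyl stays within the scatter (a 1.1-fold lower number from compound 1 to compound 4 (0.04 log units; within the scatter)), so at this position the read-out holds when the group grows from 5 to 8 heavy atoms and gains a six-membered ring of carbon only. Changing only the ring, with cyclohexyl in place of cyclopentyl, gives a small step that is printed as beyond the scatter (a 2.0-fold lower number from compound 2 to compound 4 (0.31 log units; beyond the scatter)). The step from the isopropylamino compound is larger (a 3.8-fold higher number from compound 3 to compound 4 (0.58 log units; beyond the scatter)), but it changes the ring and the amine together and cannot separate the two.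

On these data alone, it remains open whether an isopropyl group on the amine of compound 4, or a phenyl ring in place of its cyclohexyl, would shift the number, and no measurement offered here explains the size of any of these steps.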